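The source may report more compounds than this note shows. Statements on the series, on what has been measured and on what is new or still open speak of the compounds shown alone.

Working notes on the series: in a functional assay on HepG2 cells (Homo sapiens) for antiproliferative activity, read by MTT assay, with a stated time of 72 h (on this read-out lower numbers stand for stronger inhibition and higher numbers for weaker inhibition), compound 1 `O=C(N/N=C/c1ccc(F)cc1)Nc1ccc(Oc2ccnc3[nH]ccc23)cc1` gives 3430 nM and compound 2 `O=C(N/N=C/c1ccc([N+](=O)[O-])cc1)Nc1ccc(Oc2ccnc3[nH]ccc23)cc1` gives 4620 nM. Compound 3 `O=C(N/N=C/c1cccc(Cl)c1Cl)Nc1ccc(Oc2ccnc3[nH]ccc23)cc1` is recorded as "not active" (no number reported), with no number, so it offers no starting value for a step. Compound 4 `COc1ccc(/C=N/NC(=O)Nc2ccc(Oc3ccnc4[nH]ccc34)cc2)cc1` differs from compound 3 as follows: 4-methoxyphenyl in place of 2,3-dichlorophenyl on a carbon with a double bond to nitrogen. Going by the values given here, the only measured step is a 1.3-fold higher number from compound 1 to compound 2 (0.13 log units; within the scatter), for nitro in place of fluoro on an aromatic carbon. That step does not involve either group exchanged here, so it bears only indirectly, and no step size in this assay can be derived. A number close to those of the two measured compounds seems likeliest, although a result without a number remains possible. Compound 4 is expected at about 4000 nM, with an estimated range of 1500 nM to 12000 nM.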

Compound 4, half-maximal inhibitory concentration: 9740 nM
Compound 4: the middle estimate sits 2.4-fold (0.39 log units) below what was measured, and the stated range covers the measured number.
By their numbers in this assay, from the lowest: compounds 1 and 2 (each within the scatter of the next); then compound 4.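

In this assay, going by these compounds alone, a change of the aromatic substituent moves the number beyond the scatter for the first time: methoxy in place of nitro gives a 2.1-fold higher number from compound 2 to compound 4 (0.32 log units; beyond the scatter) and methoxy in place of fluoro gives a 2.8-fold higher number from compound 1 to compound 4 (0.45 log units; beyond the scatter), both modest. The step between 2,3-dichlorophenyl and 4-methoxyphenyl cannot be read, since compound 3 has no number. No available data explain these steps.

Still open, as far as these compounds go, is how an amine or a carboxylic acid on that aromatic ring would compare. Also open, from the compounds shown here alone, is whether a methoxy group elsewhere on the ring would give a similar number.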